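The source may report more compounds than this note shows. Statements on the series, on what has been measured and on what is new or still open speak of the compounds shown alone.

Measured so far:
compound 1 `CC1(C)C=C(n2ccccc2=O)c2cc(C(=O)c3ccc(O)cc3)ccc2O1` gives 5.87
compound 2 `CC1(C)C=C(n2ccccc2=O)c2cc(C(=O)c3ccc([N+](=O)[O-])cc3)ccc2O1` gives 6.09
compound 3 `CC1(C)C=C(n2ccccc2=O)c2cc(C(=O)c3ccccc3[N+](=O)[O-])ccc2O1` gives 5.64

In a functional assay (trachea) with Rattus norvegicus as the target (a higher number here means a more potent compound, by a factor of ten per unit of this negative logarithm, a lower number a less potent compound), compound 1 stands second highest of these three numbers, but its neighbours are close: the step of a number 0.22 log units higher from compound 1 to compound 2 (within the scatter) and the step of a number 0.23 log units lower from compound 1 to compound 3 (within the scatter) both lie within the scatter, so compound 1 cannot be ranked against either of the other two. Going by the values given here, the only step beyond the scatter is a number 0.45 log units lower from compound 2 to compound 3 (beyond the scatter), and it is modest.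

Compound 4 `CC1(C)C=C(n2ccccc2=O)c2cc(C(=N)S)ccc2O1` differs from compound 1 by a group of 3 heavy atoms (1 carbon, 1 nitrogen, 1 sulfur; no ring) in place of a group of 9 heavy atoms (7 carbon, 2 oxygen; one six-membered aromatic ring of carbon only), on an aromatic carbon. Among the compounds with values here, none of the measured steps is of this kind: each of them changes only a substituent on the aromatic ring that is removed here, while in compound 4 the whole (4-hydroxyphenyl)carbonyl group is gone. The measured steps show that changes within that ring shift the number only a little; they say nothing about losing the ring entirely. The expected step is therefore uncertain, a number 0.57 log units lower from compound 1 to compound 4 (beyond the scatter), and the range is wide. Compound 4 is estimated at 5.3, between 4.6 and 6.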

Compound 4, logarithm of the reciprocal of the active concentration, log(1/C): 5.96
The estimate for compound 4 lay 0.66 log units below the measured number; the measured number falls inside the stated range.
By their numbers in this assay, from the lowest: compounds 3, 1, 4 and 2 (each within the scatter of the next, the first and the last beyond it).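

Swapping the whole (4-hydroxyphenyl)carbonyl group on this aromatic carbon for a group of 3 heavy atoms with no ring gives, in this assay, a number 0.09 log units higher from compound 1 to compound 4 (within the scatter), a step that stays within the scatter. The earlier steps shown here changed only the substituents on that six-membered aromatic ring, whereas this one shows that, for this single replacement, the number holds with the carbonyl and the ring gone altogether. No available data explain why two groups of such different size give such similar numbers.

This one step removes the ring and the carbonyl together, leaving open whether the sulfur or the nitrogen of the new group matters, or whether any small group would serve here. An amine, a carboxylic acid or a nitrile on this same aromatic carbon would help to separate these possibilities.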